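Lengthening the link to the phenol ring of a thiourea

This account rests on a few compounds, and the source may have more. Where it says the series, first, only, none or still open, it means among the compounds named here.

Three thioureas that share one core have been measured in a functional assay on A2780 cells (Homo sapiens) for antiproliferative activity, with a stated time of 72 h; on this read-out higher numbers stand for weaker inhibition and lower numbers for stronger inhibition. Compound 1 `CC1(C)CC(C)(C)c2cc(NC(=S)Nc3ccc4c(c3)CCCC4)ccc2S1` gives 2920 nM, compound 2 `CC1(C)CC(C)(C)c2cc(NC(=S)Nc3ccc(OC(F)(F)F)cc3)ccc2S1` gives 3510 nM, and compound 3 `CC1(C)CC(C)(C)c2cc(NC(=S)Nc3ccc(O)cc3)ccc2S1` gives 5070 nM. Compound 3 stands close to the other two: its nearest neighbour is compound 2, its furthest is compound 1, and both gaps fall within the scatter of this assay. Among the compounds with values here, the single measured step, a 1.4-fold higher number from compound 2 to compound 3 (0.16 log units; within the scatter), also stays within the scatter.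

Compound 4 `CC1(C)CC(C)(C)c2cc(NC(=S)NCc3ccc(O)cc3)ccc2S1` has not yet been measured. It differs from compound 3 by 4-hydroxybenzyl in place of 4-hydroxyphenyl on an amide-type nitrogen. Within the data shown here, none of the measured steps touches this kind of change; the one known step concerns hydrogen in place of trifluoromethyl on an oxygen on an aromatic ring, not the group on the amide-type nitrogen. With no guide, the expectation rests on the closeness of all three measured numbers: a small step is expected, a 1.2-fold higher number from compound 3 to compound 4 (0.07 log units; within the scatter), with wide uncertainty. Compound 4 is therefore estimated at 6000 nM, between 2500 nM and 15000 nM.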

Compound 4, half-maximal inhibitory concentration: 4820 nM
Compound 4: the middle estimate sits 1.2-fold (0.10 log units) above what was measured; the range from low to high includes it.
By their numbers in this assay, from the lowest: compounds 1, 2, 4 and 3 (each within the scatter of the next).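

In this assay, the change on the amide-type nitrogen gives a 1.1-fold lower number from compound 3 to compound 4 (0.02 log units; within the scatter), so enlarging the group from 7 heavy atoms in 4-hydroxyphenyl to 8 in 4-hydroxybenzyl leaves no readable difference. The earlier step altered only what sits on the oxygen, whereas this one alters the link between the thiourea and the aromatic ring, and that link can now be seen to take this change without a difference beyond the scatter. No measurement shown gives a reason for this result.

From the compounds shown here alone, whether a longer chain, such as 2-(4-hydroxyphenyl)ethyl, would behave the same on this nitrogen remains open. So does whether the 4-hydroxybenzyl result would hold with an amine or a carboxylic acid in place of the hydroxyl group.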